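The compounds below may be only part of what the source reports. "The series", "measured", "known", "first", "only" and "open" are said of these compounds alone.

Working notes on the series. Going by the values given here, in a functional assay on NCI/ADR-RES cells (Homo sapiens) for inhibition, read by sulforhodamine B assay, with a stated time of 48 h (a lower number here means a stronger inhibitor of growth, a higher number a weaker inhibitor of growth), compound 1 `CC1(/C=C/c2ccccc2)C=CC(=O)O1` gives 414000 nM, the higher of the two numbers measured so far. Compound 2 `CC1(/C=C/c2ccccc2C(F)(F)F)C=CC(=O)O1` gives 12200 nM. Compound 3 `CC1(/C=C/c2ccc(C(F)(F)F)cc2)C=CC(=O)O1` has not yet been measured. It differs from compound 1 as follows: trifluoromethyl in place of hydrogen on an aromatic carbon. In words, trifluoromethyl stands in place of hydrogen on an aromatic carbon, para to a group of 9 heavy atoms.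

Among the compounds with values here, only one measured step bears on this change. The same replacement at a different aromatic carbon gave a 34-fold lower number from compound 1 to compound 2 (1.53 log units; beyond the scatter). A large step to a lower number is therefore expected in this assay, although a single precedent leaves its size uncertain. Compound 3 is estimated at 25000 nM, with an expected range of 6000 nM to 120000 nM. The estimated step is a 17-fold lower number from compound 1 to compound 3 (1.22 log units; beyond the scatter).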

Compound 3, concentration for total growth inhibition: 9400 nM
The estimate for compound 3 lay 2.7-fold (0.42 log units) above the measured number; low and high end bracket the measured number.
By their numbers in this assay, from the lowest: compounds 3 and 2 (each within the scatter of the next); then compound 1.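

In this assay, the step of a 44-fold lower number from compound 1 to compound 3 (1.64 log units; beyond the scatter) shows that the large drop is not confined to the aromatic carbon carrying trifluoromethyl in compound 2, as it also appears with trifluoromethyl para to a group of 9 heavy atoms. Compounds 3 and 2 stand within the scatter of each other, so these two placements of trifluoromethyl cannot be told apart in this assay. Nothing measured here accounts for the step or for this agreement.

As far as these compounds go, whether an amine, a carboxylic acid or a single fluorine at this same aromatic carbon would give a step of similar size remains open. Also open, from the compounds shown here alone, is whether a longer chain in place of the methyl on the shared core would move the number as far.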